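Swapping a Carboxy Group for a Hydroxyethyl Chain

The source may hold more compounds than are shown below. What is called first, only, known or untested is meant among the compounds shown, and "the series" means these compounds.

Compound 1 `CCCCCCCOc1ccc(CCC(N)(CO)CO)cc1` gives 0.014 mg/kg in a functional assay on the whole organism (spleen, spleen) with Rattus norvegicus as the target; on this read-out higher numbers stand for an effect only at larger amounts of compound and lower numbers for an effect already at smaller amounts. Compound 3 `CCCCCCCOc1ccc(CC[C@@](N)(CO)CCC)cc1` gives 4.4 mg/kg, and the change is a 310-fold higher number from compound 1 to compound 3 (2.50 log units; beyond the scatter). Compound 2 `CCCCCCCCc1ccc(CCC(N)(CO)C(=O)O)cc1` reaches only the limit of the assay at > 10 mg/kg, so no number is known for it (the limit of > 10 mg/kg in this assay, at which 1 of the 3 values shown sits). Compound 4 `CCCCCCCCc1ccc(CCC(N)(CO)CCO)cc1` differs from compound 2 in one place: 2-hydroxyethyl in place of carboxy on a saturated chain carbon bound to an amine nitrogen and two saturated chain carbons. Going by the values given here, the only measured step touches the same carbon next to the amine and was large, so a change here can move the read-out strongly. Given that compound 2 sits at the limit, compound 4 is expected to give a lower number, a step of an at least 100-fold lower number from compound 2 to compound 4 (2.00 log units; beyond the scatter). The estimate for compound 4 is 0.1 mg/kg, between 0.02 mg/kg and 1 mg/kg.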

Compound 4, dose for 50% inhibition: 0.12 mg/kg
Compound 4: the middle estimate sits 1.2-fold (0.08 log units) below what was measured, and the stated range covers the measured number.
By their numbers in this assay, from the lowest: compound 1; then compound 4; then compound 3. At a limit, above all of these: compound 2.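

Compound 2 stands at a limit, not at a number: the limit of > 10 mg/kg in this assay, at which 1 of the 4 values shown sits. Even so, placing 2-hydroxyethyl where carboxy stood on this carbon gives an at least 83-fold lower number from compound 2 to compound 4 (1.92 log units; beyond the scatter) in this assay, so a change here can lower the number as well as raise it. The two groups match in heavy atoms, hydrogen-bond donors and hydrogen-bond acceptors, so those counts do not separate them. On these data alone, what remains open is how a primary amide or a longer chain such as 3-hydroxypropyl would read on this carbon. The compounds shown also leave open whether the hydroxyl at the end of the 2-hydroxyethyl chain is needed, which a plain ethyl group would test.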